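The compounds below may be only part of what the source reports. "The series", "measured", "known", "first", "only" and "open" are said of these compounds alone.

Measured compounds:
compound 1 `OC[C@H]1O[C@@H](n2cnc3c(NCc4ccc(Cl)cc4)ncnc32)[C@H](O)[C@@H]1O` — > 166000 nM
compound 2 `OC[C@H]1O[C@@H](n2cnc3c(NCc4ccc(Br)cc4)ncnc32)[C@H](O)[C@@H]1O` — > 166000 nM
compound 3 `OC[C@H]1O[C@@H](n2cnc3c(NCc4ccc(F)cc4F)ncnc32)[C@H](O)[C@@H]1O` — > 166000 nM

The assay is a functional assay on HOS cells (Homo sapiens) for antiproliferative activity, with a stated time of 72 h; a higher number here means a weaker inhibitor, a lower number a stronger inhibitor. In this assay compound 1 gives only a limit, > 166000 nM, and no number. Compound 2 likewise gives only a limit in this assay, > 166000 nM. Compound 3 gives only a limit too, > 166000 nM. Compound 2 therefore stands at the limit, as do the other two values shown, so nothing places it above or below them. The step from bromo to chloro reads a step that the two limits leave unreadable from compound 1 to compound 2; the steps to the 2,4-difluorophenyl compound read a step that the two limits leave unreadable from compound 1 to compound 3 and a step that the two limits leave unreadable from compound 2 to compound 3. All three sit at the limit of > 166000 nM in this assay, at which 3 of the 3 values shown sit, so their size cannot be read.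

The compound still to be measured is compound 4 `OC[C@H]1O[C@@H](n2cnc3c(NCc4cccc(O)c4O)ncnc32)[C@H](O)[C@@H]1O`. It differs from compound 2 as follows: 2,3-dihydroxyphenyl in place of 4-bromophenyl on a saturated chain carbon bound to a nitrogen on an aromatic ring. No measured step touches a dihydroxyphenyl group, so none of the shown steps can be read for direction or size; the only guidance is that compound 2 and its two relatives all sit at the limit. The expected step in this assay from compound 2 to compound 4 is therefore an at least 1.1-fold lower number from compound 2 to compound 4 (0.04 log units; that floor lies within the scatter), with a sizeable chance that only a limit is reported again. Compound 4 is estimated at 150000 nM, in a range from 30000 nM to 500000 nM.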

Compound 4, half-maximal inhibitory concentration: > 166000 nM
Compound 4 was reported as a limit (the forecaster's own chance of this, stated with the estimate: 70%); middle value at least 1.1-fold (0.04 log units) away from the limit.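

In this assay compound 4 gives only a limit (> 166000 nM). Going by these compounds alone, no step among compound 1, compound 2, compound 3 and compound 4 can be read, since all four stand at the same limit: the limit of > 166000 nM in this assay, at which 4 of the 4 values shown sit. Going by these compounds, whether this assay can return a number rather than a limit for any group in this place stays open.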